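The source may hold more compounds than are shown below. What is called first, only, known or untested is meant among the compounds shown, and "the series" means these compounds.

Measured compounds:
Compound 1, `CS(=O)(=O)c1ccc(C(=O)NCCC(=O)N2CCc3ccccc32)cc1[N+](=O)[O-]`, gives > 60000 nM in an assay on isolated protein for inhibition of thyroid hormone receptor alpha (Homo sapiens), read by fluorescence polarization (a higher number here means a weaker inhibitor, a lower number a stronger inhibitor), which is a limit of the assay rather than a number.
Compound 2, `CC(C)N(C(=O)CCNC(=O)c1ccc(S(C)(=O)=O)c([N+](=O)[O-])c1)C(C)C`, gives > 60000 nM in this assay, again a limit.

Compound 2 therefore has no fixed place on the scale: it lies at the limit of > 60000 nM in this assay, at which 2 of the 2 values shown sit. Among the measured compounds shown here, the only step so far, a step that the two limits leave unreadable from compound 1 to compound 2, is hidden by the two limits. Compound 3, `CS(=O)(=O)c1ccc(C(=O)NCCC(=O)N2CCc3ccccc3C2)cc1[N+](=O)[O-]`, differs from compound 2 in one place: 1,2,3,4-tetrahydroisoquinolin-2-yl in place of diisopropylamino on a carbonyl carbon. For the measured compounds named here, the single step on record bears directly on this change, but its size cannot be read, so nothing sets either the direction or the size of the step into compound 3. Compound 1, carrying a 2,3-dihydro-1H-indol-1-yl group on the same carbonyl carbon, also sits at > 60000 nM. Compound 3 is therefore expected to remain at the limit as well, an expected step that the limit leaves unreadable from compound 2 to compound 3. The estimate for compound 3 is 100000 nM, within 30000 nM to 400000 nM.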

Compound 3, half-maximal inhibitory concentration: > 60000 nM
Compound 3 gave a limit, no number (the forecaster's own chance of this, stated with the estimate: 85%); the middle value is on the limit's open side.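

Compound 3 gives a limit of the assay rather than a number, so the steps to it from compound 1 and compound 2 cannot be read: the limit of > 60000 nM in this assay, at which 3 of the 3 values shown sit.

In this assay the compounds shown leave open how strongly each one inhibits, and whether changing the group on the carbonyl carbon makes any difference.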